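Swapping Chloro for Bromo on the Shared Core

The source may report more compounds than this note shows. Statements on the series, on what has been measured and on what is new or still open speak of the compounds shown alone.

Compound 1 `N#CC1=C(N)Oc2cc3oc(-c4ccccc4)cc(=O)c3c(O)c2C12C(=O)Nc1ccccc12` is the starting point. In a functional assay on PC-3 cells (Homo sapiens) for antiproliferative activity, read by MTT assay, with a stated time of 48 h (on this read-out lower numbers stand for stronger inhibition and higher numbers for weaker inhibition), compound 1 reaches only a limit, > 50000 nM. Among the compounds with values here, compound 2 `N#CC1=C(N)Oc2cc3oc(-c4ccccc4)cc(=O)c3c(O)c2C12C(=O)Nc1cc(Cl)ccc12` carries chloro in place of hydrogen on an aromatic carbon, and in this assay compound 2 gives 25700 nM, the only definite number so far. The measured step of an at least 1.9-fold lower number from compound 1 to compound 2 (0.28 log units; that floor lies within the scatter) begins at a limit (the limit of > 50000 nM in this assay, at which 1 of the 2 values shown sits). Compound 3 `N#CC1=C(N)Oc2cc3oc(-c4ccccc4)cc(=O)c3c(O)c2C12C(=O)Nc1cc(Br)ccc12` differs from compound 2 by bromo in place of chloro on an aromatic carbon. Within the data shown here, no measured step exchanges one halogen for another, and the one step known is modest. The expected step is therefore a 1.3-fold lower number from compound 2 to compound 3 (0.11 log units; within the scatter), within the scatter. For compound 3 the estimate is 20000 nM, between 8000 nM and 50000 nM.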

Compound 3, half-maximal inhibitory concentration: 24800 nM
For compound 3 the middle estimate is 1.2-fold (0.09 log units) below the measured one; the range from low to high includes it.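

In this assay, exchanging one halogen for the other at this aromatic carbon changes nothing that can be told apart: a 1.0-fold lower number from compound 2 to compound 3 (0.02 log units; within the scatter). Bromo in place of hydrogen gives an at least 2.0-fold lower number from compound 1 to compound 3 (0.30 log units; that floor lies within the scatter), so bromo, like chloro, shows no step beyond the scatter. Compound 1 reaches only a limit, not a number: the limit of > 50000 nM in this assay, at which 1 of the 3 values shown sits.

Going by these compounds, how an amine, a methoxy group or a carboxylic acid on this same aromatic carbon would read in this assay remains open. So does whether any group here can move the number beyond the scatter.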